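The source may hold more compounds than are shown below. What is called first, only, known or untested is meant among the compounds shown, and "the series" means these compounds.

Measured in a functional assay on BXPC-3 cells (Homo sapiens) for antiproliferative activity, read by MTT assay, with a stated time of 24 h; a lower number here means a stronger inhibitor, a higher number a weaker inhibitor:
compound 1 `CCN(CC)CCNC(=O)c1ccc(C(CC)(CC)c2ccc(OCS(=O)(=O)c3ccccc3)c(C)c2)n1CC` gives 6270 nM
compound 2 `CCn1c(C(=O)NC(C)(C)CO)ccc1C(CC)(CC)c1ccc(OCS(=O)(=O)c2ccccc2)c(C)c1` gives 18300 nM
compound 3 `CCn1c(C(=O)NC2(CO)CC2)ccc1C(CC)(CC)c1ccc(OCS(=O)(=O)c2ccccc2)c(C)c1` gives 45400 nM

The three compounds differ only in the group on the amide-type nitrogen. Compound 3 has the highest number of the three, making it the weakest inhibitor in this assay. Compound 4 `CCn1c(C(=O)N[C@@H](CO)CCCO)ccc1C(CC)(CC)c1ccc(OCS(=O)(=O)c2ccccc2)c(C)c1` changes that same group again: a group of 7 heavy atoms (5 carbon, 2 oxygen; no ring) in place of a group of 5 heavy atoms (4 carbon, 1 oxygen; one three-membered non-aromatic ring of carbon only), on an amide-type nitrogen. The 1-(hydroxymethyl)cyclopropyl group leaves, and with it the three-membered ring, while the group that enters has no ring and one defined stereocentre.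

Among the compounds with values here, three measured steps bear on this change, all at the same nitrogen. The closest is a 2.5-fold higher number from compound 2 to compound 3 (0.39 log units; beyond the scatter), which links two groups of similar size. The two steps from the diethylamino compound are a 2.9-fold higher number from compound 1 to compound 2 (0.47 log units; beyond the scatter) and a 7.2-fold higher number from compound 1 to compound 3 (0.86 log units; beyond the scatter). Within the data shown here, both compounds without a ring in this group have lower numbers than compound 3, although only three compounds support this observation. Among the measured compounds shown here, no measured compound carries a group resembling the one entering compound 4, so the evidence is indirect. A modest step toward a lower number is therefore expected, estimated as a 2.3-fold lower number from compound 3 to compound 4 (0.36 log units; beyond the scatter). The estimated value for compound 4 is 20000 nM, with an expected range of 7000 nM to 60000 nM.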

Compound 4, half-maximal inhibitory concentration: 16400 nM
Estimate against measurement, compound 4: 1.2-fold (0.09 log units) above; the range from low to high includes it.
By their numbers in this assay, from the lowest: compound 1; then compounds 4 and 2 (each within the scatter of the next); then compound 3.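

In this assay, within the data shown here, the change of group gives a 2.8-fold lower number from compound 3 to compound 4 (0.44 log units; beyond the scatter), so a second group without a ring, alongside that of compound 2, now has a lower number than the 1-(hydroxymethyl)cyclopropyl group; among the four compounds, the only one carrying a ring in this group has the highest number. Replacing the 1-(hydroxymethyl)-1-methylethyl group with the entering group, which has more heavy atoms, more hydrogen-bond donors and acceptors, and one defined stereocentre, gives a 1.1-fold lower number from compound 2 to compound 4 (0.05 log units; within the scatter), so these differences leave no readable change between those two compounds. The group of compound 4 and the 2-(diethylamino)ethyl group both have 7 heavy atoms, yet the measured step is a 2.6-fold higher number from compound 1 to compound 4 (0.42 log units; beyond the scatter), which shows that heavy-atom count alone does not set the number at this nitrogen and leaves compound 1 with the lowest number of the four.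

The compounds shown leave open whether the defined stereocentre of compound 4 matters, and what a longer chain ending in a primary amine or a carboxylic acid would give on this amide-type nitrogen. Nothing measured here accounts for any of these differences.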